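Methoxy in Place of Chloro on the Aryl Ring

The source may report more compounds than this note shows. Statements on the series, on what has been measured and on what is new or still open speak of the compounds shown alone.

Of the compounds shown here, three sharing one core have been tested in a functional assay on the whole organism for positive allosteric modulation, with Rattus norvegicus as the target; on this read-out higher numbers stand for an effect only at larger amounts of compound and lower numbers for an effect already at smaller amounts. Compound 1 `CC(=O)N1CCN=C(c2cccc(Cl)c2)c2c(C)nn(C)c21`, which bears an acetyl group on its core, reaches only a limit of > 10 mg/kg in this assay; that value is the limit of > 10 mg/kg in this assay, at which 1 of the 3 values shown sits. Compound 2 `Cc1nn(C)c2c1C(c1ccc(Cl)c(Cl)c1)=NCCN2` gives 2.5 mg/kg in this assay. Compound 3 `Cc1nn(C)c2c1C(c1ccc(Cl)cc1)=NCCN2` gives 2.5 mg/kg in this assay. Among the measured compounds shown here, the single measured step, no change at the digits printed from compound 2 to compound 3 (within the scatter), shows that removing one chloro from the aryl ring leaves the dose unchanged, so compound 3 stands level with compound 2 among the numbers known.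

Compound 4 `COc1ccc(C2=NCCNc3c2c(C)nn3C)cc1` is not yet measured. It differs from compound 3 as follows: methoxy in place of chloro on an aromatic carbon. For the measured compounds named here, the only step that bears on this change is the one from compound 2 to compound 3, a swap at an aromatic carbon of the same ring, and it was within the scatter. Going by the values given here, no measured step covers a methoxy group, so the expectation rests on that flat step alone: the step of a 1.2-fold higher number from compound 3 to compound 4 (0.08 log units; within the scatter) is expected to stay within the scatter. Compound 4 is therefore estimated to give 3 mg/kg in this assay, with a range of 1.25 mg/kg to 10 mg/kg.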

Compound 4, minimum effective dose: > 10 mg/kg
Compound 4: no number, only a limit (the forecaster's own chance of this, stated with the estimate: 25%); middle value at least 3.3-fold (0.52 log units) away from the limit.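

In this assay, methoxy in place of chloro on an aromatic carbon, para to a large group, gives an at least 4.0-fold higher number from compound 3 to compound 4 (0.60 log units; beyond the scatter), so this place on the ring is not indifferent to what stands there. Among the compounds shown here, the only earlier step on this ring, no change at the digits printed from compound 2 to compound 3 (within the scatter), showed that one chloro can go while the other stays, and it said nothing about replacing the chloro that compound 3 keeps. The value of compound 4 is a limit and not a number, so the step has only a lower bound and its full size stays unknown: the limit of > 10 mg/kg in this assay, at which 2 of the 4 values shown sit.

The compounds shown leave open which part of the change counts, the hydrogen-bond acceptor that enters with methoxy or its second heavy atom. A methyl, a fluoro or a hydroxy at this place could separate the two, and a plain hydrogen there would show whether the chloro of compound 3 is needed at all or whether only methoxy is poorly accepted.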